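This account rests on a few compounds, and the source may have more. Where it says the series, first, only, none or still open, it means among the compounds named here.

Three members of the series have been run in a functional assay on A549 cells (Homo sapiens) for inhibition, tested at 100 uM; a lower number here means a weaker effect, a higher number a stronger effect of the compound at the concentration tested. Among the compounds with values here, compound 1 `Cc1ccc(S(=O)(=O)n2cc(-c3cc(C(F)(F)F)c(C#N)c(-c4cn(S(=O)(=O)c5ccc(C)cc5)c5ccc(Br)cc45)n3)c3cc(Br)ccc32)cc1` gives 70.6% and compound 2 `Cc1ccc(S(=O)(=O)n2cc(-c3cc(C(F)(F)F)cc(-c4cn(S(=O)(=O)c5ccc(C)cc5)c5cc(Br)ccc45)n3)c3ccc(Br)cc32)cc1` gives 49.2%; these two differ in more than one place, so their values show only that compound 1 sits higher. Compound 3 `COc1ccc2c(c1)c(-c1cc(C(F)(F)F)c(C#N)c(-c3cn(S(=O)(=O)c4ccc(C)cc4)c4ccc(OC)cc34)n1)cn2S(=O)(=O)c1ccc(C)cc1` gives 17.7%, the lowest of the three, beyond the scatter below both others. Compound 4 `COc1ccc2c(c1)c(-c1cc(C(F)(F)F)cc(-c3cn(S(=O)(=O)c4ccc(C)cc4)c4ccc(OC)cc34)n1)cn2S(=O)(=O)c1ccc(C)cc1` is the next entry: hydrogen in place of cyano on an aromatic carbon. Within the data shown here, no single-change step between measured compounds anchors the size of this change in this assay. Compound 3 is already a weak read-out, leaving little room below it. A small downward step or none beyond the scatter is expected, a number 7.7 percentage points lower from compound 3 to compound 4 (within the scatter). Compound 4 is estimated at 10%, with a range from 0% to 28%.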

Compound 4, a percentage reported as inhibition, at one concentration (the size of the read-out at that concentration, not a potency): 41.7%
For compound 4 the middle estimate is 31.7 percentage points below the measured one, outside the stated range (above it).
By their numbers in this assay, from the lowest: compound 3; then compounds 4 and 2 (each within the scatter of the next); then compound 1.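

Within the data shown here, replacing cyano with hydrogen on this aromatic carbon, ortho to a trifluoromethyl group, gives the first single-change step: in this assay, a number 24 percentage points higher from compound 3 to compound 4 (beyond the scatter). The position is therefore not silent on this core, and here the cyano-bearing compound 3 is the one with the weaker read-out. No measurement on hand accounts for this step.

On these data alone, whether an amine or a carboxylic acid on this carbon would read closer to compound 3 or compound 4 stays open. So does whether the step carries over to the cores of compound 1 and compound 2.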